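A few compounds are considered here, and "the series" means these few. Any claim that something is new, unique, unknown or untested is made for them only; others in the source may bear on it.

Measured so far:
Compound 1 (`C=C(c1cc(OC)c(OC)c(OC)c1)c1ccc(OC)cc1NC(=O)CN`): 190 nM
Compound 2 (`C=C(c1cc(OC)c(OC)c(OC)c1)c1ccc(OC)cc1NC(=O)CNC`): 240 nM

In a functional assay on MCF7 cells (Homo sapiens) for antiproliferative activity, read by MTT assay, with a stated time of 48 h (on this read-out lower numbers stand for stronger inhibition and higher numbers for weaker inhibition), compound 2 stands at 240 nM and shares its place with compound 1 at 190 nM within the usual scatter of the read-out. Compound 3 (`C=C(c1cc(OC)c(OC)c(OC)c1)c1ccc(OC)cc1NC(=O)CNCC`) has not yet been measured. It departs from compound 2 by a single change (methyl in place of hydrogen on a saturated chain carbon bound to an amine nitrogen), methyl in place of hydrogen on a saturated chain carbon bound to an amine nitrogen, which turns methylamino into ethylamino.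

Among the compounds with values here, the one measured step that bears on this is a 1.3-fold higher number from compound 1 to compound 2 (0.10 log units; within the scatter) and it is methyl in place of hydrogen on an amine nitrogen. Within the data shown here, it touches the same amine but not the same place, and no step at the chain carbon has been measured, so the support is thin. In this assay, from the compounds shown here alone, no step beyond the scatter is therefore expected, and the direction remains open. The expected step is a 1.1-fold higher number from compound 2 to compound 3 (0.03 log units; within the scatter) and it would stay within the scatter. For compound 3 the estimated value is 260 nM with an expected range from 110 nM to 600 nM in this read-out.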

Compound 3, half-maximal inhibitory concentration: 860 nM
Estimate against measurement, compound 3: 3.3-fold (0.52 log units) below, and the stated range ends below it.
By their numbers in this assay, from the lowest: compounds 1 and 2 (each within the scatter of the next); then compound 3.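

In this assay, the amine nitrogen of this side chain turns out not to accept every small group equally: methylamino left the number within the scatter, with a 1.3-fold higher number from compound 1 to compound 2 (0.10 log units; within the scatter), whereas the change from methylamino to ethylamino gave a 3.6-fold higher number from compound 2 to compound 3 (0.55 log units; beyond the scatter). Taken from the unsubstituted amine, ethyl in place of hydrogen on the amine nitrogen amounts to a 4.5-fold higher number from compound 1 to compound 3 (0.66 log units; beyond the scatter), so on this read-out the ethylamino compound inhibits more weakly than either of the other two, and methyl in place of hydrogen on a saturated chain carbon bound to an amine nitrogen is the one change here that moves the number beyond the scatter. Nothing at hand accounts for this loss, and no measurement outside the numbers themselves bears on it.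

The three compounds leave open whether the number keeps rising with a propyl chain or a branched isopropyl group on the same nitrogen, or whether the loss is confined to ethylamino. They also leave open how dimethylamino or a ring amine such as pyrrolidine would stand in this place, and whether the same step holds on any other core or read-out.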